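A Stereocentre Flip in a Dopamine Transporter Series

The compounds below may be only part of what the source reports. "The series", "measured", "known", "first", "only" and "open" are said of these compounds alone.

In a functional assay on striatum for inhibition of sodium-dependent dopamine transporter (Rattus norvegicus) (on this read-out higher numbers stand for weaker inhibition and lower numbers for stronger inhibition), compound 1 `CN[C@@H]1CC[C@@H](c2ccc(F)cc2)c2ccccc21` gives 220 nM. Compound 2 `CN(C)[C@@H]1CC[C@@H](c2ccccc2)c2ccccc21` gives 840 nM in this assay, the higher of the two numbers, and its gap to compound 1 lies beyond the usual scatter. Compound 3 `CN(C)[C@H]1CC[C@@H](c2ccccc2)c2ccccc21` differs from compound 2 only in configuration: the two compounds have the same atoms and bonds and differ only in configuration as drawn: 1 of 2 stereo elements differ; a stereocentre at a saturated ring carbon is drawn R in compound 2 and S in compound 3. Going by the values given here, no measured pair shows the effect of such a change here. The author expects compound 3 to be weaker, with an estimated step of a 3.6-fold higher number from compound 2 to compound 3 (0.55 log units; beyond the scatter) in this assay beyond the scatter. Compound 3 is therefore estimated at 3000 nM, within a range from 800 nM to 12000 nM.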

Compound 3, half-maximal inhibitory concentration: 10000 nM
Estimate against measurement, compound 3: 3.3-fold (0.52 log units) below; measured number inside the range.
By their numbers in this assay, from the lowest: compound 1; then compound 2; then compound 3.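

In this assay, going by these compounds alone, changing the saturated ring carbon stereocentre from R to S gives a 12-fold higher number from compound 2 to compound 3 (1.08 log units; beyond the scatter), so this position is sensitive to configuration alone, which the earlier compounds could not show. The weaker inhibition can be assigned to this stereocentre alone because nothing else in the structure changes: the fact that compounds 2 and 3 differ only in the configuration as drawn

As far as these compounds go, the contribution of the second stereocentre remains open. So does whether the same preference would hold with a primary amine in place of the dimethylamino group.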